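This account rests on a few compounds, and the source may have more. Where it says the series, first, only, none or still open, it means among the compounds named here.

Two esters of the series have been run so far, both carrying the same cinnamyl alcohol part and differing only in the aryl group of the acid. Compound 1 `COc1cc(OC)c(OC)cc1/C=C/COC(=O)/C=C/c1c(OC)ccc(OC)c1OC` in a functional assay on the whole organism (strain Kunming) with Mus musculus as the target, with a stated time of 0.5 h, at a dose of 300 mg/kg by the intraperitoneal route (on this read-out higher numbers stand for a weaker effect at the one dose given and lower numbers for a stronger effect), gives 100%. Compound 2 `COc1cc(OC)c(OC)cc1/C=C/COC(=O)/C=C/c1ccc(Br)cc1` gives in this assay 100%. Compound 2 therefore stands level with compound 1 at the digits shown, and the two values lie within the scatter of each other, so no order between them can be read from these numbers; the pair does not separate a trimethoxy-substituted aryl from a bromo-substituted one on this read-out.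

The next compound, compound 3 `COc1ccc(/C=C/C(=O)OC/C=C/c2cc(OC)c(OC)cc2OC)cc1`, is not yet measured. Against compound 2 the counted difference is methoxy in place of bromo on an aromatic carbon. Nothing measured in the series yet shows what a methoxy in place of bromo does on this read-out, and the two values in hand sit at the same level, so no step beyond the scatter is expected in this assay; the step from compound 2 to compound 3 is estimated as no change at the digits printed from compound 2 to compound 3 (within the scatter). For compound 3 the expected value in this assay is 100%, within a range of 85% to 100%.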

Compound 3, a percentage reported as activity, at one dose (the size of the read-out at that dose, not a potency): 100%
Beside the measured number, compound 3's estimate shows no gap at the digits printed, and the stated range covers the measured number.
By their numbers in this assay, from the lowest: compounds 1, 2 and 3 (each within the scatter of the next).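

In this assay, methoxy in place of bromo on an aromatic carbon, para to a large group, gives no change at the digits printed from compound 2 to compound 3 (within the scatter). Within the data shown here, this is the first step that changes one place only, so the 4-bromophenyl to 4-methoxyphenyl exchange can now be read on its own: a halogen gives way to a group that brings a hydrogen-bond acceptor, and the read-out at this single dose does not register the exchange. No measurement available here bears on the reason for this flat result, and the step alone gives no account of it.

Still open, on these data alone, is whether any group at this place can move the read-out beyond the scatter, for example an amine, a carboxylic acid or a longer chain such as butoxy in place of the methoxy of compound 3. Also open, as far as these compounds go, is whether a change in the shared cinnamyl alcohol part, such as an ester replaced by an amide, would separate compounds that this single-dose read-out leaves level so far.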